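A few compounds are considered here, and "the series" means these few. Any claim that something is new, unique, unknown or untested is made for them only; others in the source may bear on it.

Working notes on the series, read in a functional assay on A549 cells (Homo sapiens) for cytotoxicity, read by MTT assay, with a stated time of 48 h; on this read-out lower numbers stand for stronger inhibition and higher numbers for weaker inhibition. Compound 1 `COc1ccc(-c2c[nH]c(=O)n2-c2cc(OC)c(OC)c(OC)c2)cc1[N+](=O)[O-]` gives > 50000 nM, which is a limit and not a number. Compound 3 `COc1cc(-n2c(-c3ccc(Cl)cc3)cn(C(C)=O)c2=O)cc(OC)c1OC` gives > 50000 nM, which is also a limit and not a number. Going by these compounds, compound 3 therefore stands at the limit of > 50000 nM in this assay, at which 2 of the 3 values shown sit, and its true position is unknown. Among the measured compounds shown here, compound 2 `COc1ccc(-c2cn(C(=O)Nc3cc(OC)c(OC)c(OC)c3)c(=O)n2-c2cc(OC)c(OC)c(OC)c2)cc1N` is the only compound with a measured number, at 11100 nM.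

The next step leads to compound 4 `COc1ccc(-c2cn(C(C)=O)c(=O)n2-c2cc(OC)c(OC)c(OC)c2)cc1N`, where 3-amino-4-methoxyphenyl replaces 4-chlorophenyl on an aromatic carbon, while the acetyl group stays in place: 3-amino-4-methoxyphenyl in place of 4-chlorophenyl on an aromatic carbon. For the measured compounds named here, no step between measured compounds is available to calibrate this change. Compound 2 is the nearest guide, as it carries the same 3-amino-4-methoxyphenyl group but lacks the acetyl group of compound 4. With this group, compound 2 reaches 11100 nM, so a shift towards stronger inhibition in this assay is expected. The expected step is an at least 6.2-fold lower number from compound 3 to compound 4 (0.79 log units; beyond the scatter), and its size is poorly defined on the low side. For compound 4 the estimated value is 8000 nM. The expected range for compound 4 runs from 800 nM to 50000 nM, and a result reported only as a limit remains possible.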

Compound 4, half-maximal inhibitory concentration: 1100 nM
The estimate for compound 4 lay 7.3-fold (0.86 log units) above the measured number, and the stated range covers the measured number.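

In this assay, putting 3-amino-4-methoxyphenyl in place of 4-chlorophenyl on this aromatic carbon, next to the ring nitrogen, gives an at least 45-fold lower number from compound 3 to compound 4 (1.65 log units; beyond the scatter). Among the compounds shown here, this is the first change that can be read in one place, and with the acetyl group held constant it shows that this position alone can yield a measured number, with compound 4 at 1100 nM. The size of the step is only a lower bound because compound 3 gives a limit and not a number: the limit of > 50000 nM in this assay, at which 2 of the 4 values shown sit.

The amino and methoxy groups enter together, and the compounds shown leave open which of the two carries the step; a 3-aminophenyl or a 4-methoxyphenyl group on this carbon would separate them. Also open, going by these compounds, is how far the number depends on the acetyl group, which a propanoyl group in its place would test.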